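The compounds below may be only part of what the source reports. "The series", "measured", "known", "first", "only" and "open" are said of these compounds alone.

In a functional assay on HEK293 cells for agonist activity at G-protein coupled receptor 39 (Homo sapiens), read by scintillation proximity assay and inositol phosphate accumulation, with a stated time of 75 min, in the presence of a further agent that is not named here (a lower number here means that less compound is needed, a higher number that more compound is needed for the effect), compound 2 `Cc1noc(C)c1COC1CC(=O)Nc2c1c(C)nn2-c1ncnc2nc[nH]c12` gives 5 nM. Going by the values given here, only one other compound has been measured alongside it: compound 1 `Cc1nn(-c2ncnc3nc[nH]c23)c2c1C(OCc1ccccc1C#N)CC(=O)N2`, which gives 8 nM in this assay, and the step of a 1.6-fold lower number from compound 1 to compound 2 (0.20 log units; within the scatter) is within the scatter, so the two compounds cannot be separated on these numbers. Compound 3 `Cc1nn(-c2ncnc3nc[nH]c23)c2c1C(OCc1cc(F)cc3c1OCOC3)CC(=O)N2` has not yet been measured. It differs from compound 2 in one place: a group of 11 heavy atoms (8 carbon, 2 oxygen, 1 fluorine; one six-membered non-aromatic ring with 2 hetero atoms, one six-membered aromatic ring of carbon only) in place of a group of 7 heavy atoms (5 carbon, 1 nitrogen, 1 oxygen; one five-membered aromatic ring with 2 hetero atoms), on a saturated chain carbon bound to an oxygen on a saturated carbon. Among the compounds with values here, the only measured step that bears on this position is the earlier exchange of rings on the same saturated chain carbon, which gave a 1.6-fold lower number from compound 1 to compound 2 (0.20 log units; within the scatter) without moving the number beyond the scatter. Because that exchange at the same place gave a 1.6-fold lower number from compound 1 to compound 2 (0.20 log units; within the scatter), no movement beyond the scatter is expected here either. A step of a 1.2-fold higher number from compound 2 to compound 3 (0.08 log units; within the scatter) is therefore expected. Compound 3 is estimated at 6 nM in this assay, with a range from 2 nM to 20 nM.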

Compound 3, half-maximal effective concentration: 1.5 nM
For compound 3 the middle estimate is 4.0-fold (0.60 log units) above the measured one; the whole stated range lies above it.
By their numbers in this assay, from the lowest: compound 3; then compounds 2 and 1 (each within the scatter of the next).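

In this assay, this position had so far shown only a step within the scatter, but the group of 11 heavy atoms now gives a clear change: a 3.3-fold lower number from compound 2 to compound 3 (0.52 log units; beyond the scatter), and a 5.3-fold lower number from compound 1 to compound 3 (0.73 log units; beyond the scatter). A group on the saturated chain carbon bound to an oxygen on a saturated carbon can therefore move the number, and this larger group with two rings is compatible with a lower number than either earlier group. No measurement available here explains the step.

Going by these compounds, the fluorine and the six-membered non-aromatic ring enter together, so the share of each in the step remains open. On these data alone, it is also open whether an amine or a carboxylic acid at this place would keep the number this low.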